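The compounds below may be only part of what the source reports. "The series", "measured", "known", "first", "only" and "open" are said of these compounds alone.

In a toxicity assay on THP-1 cells (Homo sapiens) for inhibition (a higher number here means that more compound is tolerated, a lower number that less compound is tolerated), compound 1 `Cn1c(-c2cccc([N+](=O)[O-])c2)cnc1NC(=O)c1ccc(F)cc1` gives > 50000 nM, which is a limit of the assay and not a number. Compound 1 thus sits at the limit of > 50000 nM in this assay, at which 1 of the 3 values shown sits. Compound 2 `COc1ccc(-c2cnc(NC(=O)C3CCCC3)n2C)cc1` in this assay gives > 100000 nM, also a limit. Compound 3 `COc1ccc(-c2cnc(NC(=O)c3ccccc3OC)n2C)cc1` gives > 100000 nM, again a limit. Two of the three values shown sit at the limit of > 100000 nM in this assay, at which 2 of the 3 values shown sit. Going by the values given here, the step that the two limits leave unreadable from compound 2 to compound 3 has limits at both of its ends and gives no size, and no other measured step is available. The unmeasured compound 4 `Cc1cccc(-c2cnc(NC(=O)c3ccc(F)cc3)n2C)c1` differs from compound 1 in one place: methyl in place of nitro on an aromatic carbon. Among the compounds with values here, no measured step bears on this change, so the only guide is that all three known compounds are tolerated up to the limit of this assay. Compound 4 is therefore expected to be tolerated in a similar way, with an estimated value of 80000 nM and a range from 30000 nM to 200000 nM. The step that the limit leaves unreadable from compound 1 to compound 4 is expected to be no real change beyond the scatter, and most likely compound 4 is again reported only as a limit.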

Compound 4, half-maximal cytotoxic concentration: > 100000 nM
Compound 4 gave a limit, no number; the forecaster's own chance of this, stated with the estimate: 75%; middle value at least 1.2-fold (0.09 log units) from the limit.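

Going by these compounds alone, compound 1 and compound 4 are both reported only as limits of the assay, so the change from nitro to methyl gives no step that can be read. The compounds shown leave open at what concentration, if any, any of the four becomes toxic to these cells.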